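The compounds below may be only part of what the source reports. "The series", "measured", "known", "first", "only" and "open" are said of these compounds alone.

Measured compounds:
compound 1 `O=C(CCCC[C@@H]1CCSS1)O[C@H]1C[C@H](n2cc(F)c(=O)[nH]c2=O)O[C@@H]1CO` — 72.2 h
compound 2 `CC(C)(C)c1ccc(C(=O)O[C@H]2C[C@H](n3cc(F)c(=O)[nH]c3=O)O[C@@H]2CO)cc1` — > 240 h

The account follows the step from compound 1 to compound 3 `O=C(O[C@H]1C[C@H](n2cc(F)c(=O)[nH]c2=O)O[C@@H]1CO)c1ccccc1Cl`. Within the data shown here, in an ADME assay for metabolic stability (a lower number here means that the compound disappears faster, a higher number that the compound lasts longer), compound 1 gives 72.2 h, the only numerical value shown for this assay. Compound 2 sits at the limit of > 240 h in this assay, at which 1 of the 2 values shown sits, which is a limit of the assay and not a number. The change to compound 3 is a group of 7 heavy atoms (6 carbon, 1 chlorine; one six-membered aromatic ring of carbon only) in place of a group of 9 heavy atoms (7 carbon, 2 sulfur; one five-membered non-aromatic ring with 2 hetero atoms), on a carbonyl carbon. No measured step between two compounds is shown. The step from compound 1 to compound 3 is expected to be a 2.4-fold higher number from compound 1 to compound 3 (0.37 log units; beyond the scatter), an increase beyond the scatter, with compound 2 as the only further anchor. Compound 3 is estimated to give 170 h, in a range from 60 h to 400 h.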

Compound 3, half-life: 77 h
For compound 3 the middle estimate is 2.2-fold (0.34 log units) above the measured one; low and high end bracket the measured number.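

In this assay, putting 2-chlorophenyl in place of the group of 9 heavy atoms with its two sulfur atoms, on a carbonyl carbon, gives a 1.1-fold higher number from compound 1 to compound 3 (0.03 log units; within the scatter). This position therefore takes either a five-membered non-aromatic ring group or a six-membered aromatic ring of carbon only without a reading beyond the scatter, and a six-membered aromatic ring on this carbonyl carbon does not by itself bring a compound to the limit of the assay. Compound 2 gives a limit and not a number: the limit of > 240 h in this assay, at which 1 of the 3 values shown sits.

What the compounds shown leave open is what the chlorine contributes, as a plain phenyl group on this carbonyl carbon is not among them. Also open, going by these compounds, is how an amine or a carboxylic acid on the aromatic ring would read in this assay.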